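The compounds below may be only part of what the source reports. "The series", "measured", "known", "first", "only" and "open" are said of these compounds alone.

In an assay on isolated protein for agonist activity at Bile acid receptor (Homo sapiens), read by FRET (on this read-out lower numbers stand for smaller maximal responses and higher numbers for larger maximal responses), three compounds have been measured. Compound 1 `CO[C@]1(c2ccc(OCc3c(-c4c(Cl)cccc4Cl)noc3C3CC3)cc2Cl)C[C@H](c2cccc(C(=O)O)c2)C1` gives 93%. Compound 2 `CC(C)n1nc(C(=O)O)cc1[C@@H]1C[C@H]1c1ccc(OCc2c(-c3c(Cl)cccc3Cl)noc2C2CC2)cc1Cl` gives 101%, and compound 3 `O=C(O)c1cncc(N2CC(O)(c3ccc(OCc4c(-c5c(Cl)cccc5Cl)noc4C4CC4)cc3Cl)C2)c1` gives 102%. Compound 1 holds the lowest of the three numbers, yet its gap to compound 2 and its gap to compound 3 both lie within the usual scatter of repeated measurements, so the three compounds cannot be told apart on this read-out.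

Compound 4 `O=C(O)c1cccc([C@H]2C[C@@H](c3ccc(OCc4c(-c5c(Cl)cccc5Cl)noc4C4CC4)cc3Cl)C2)c1` has not yet been measured in this assay. It differs from compound 1 in one place: hydrogen in place of methoxy on a saturated ring carbon. The rest of the shared core is unchanged.

Nothing measured here separates any two of the compounds beyond the scatter, and the change from compound 1 to compound 4 is small in size. Compound 4 is therefore expected to show a step of a number 3 percentage points higher from compound 1 to compound 4 (within the scatter), that is, no change beyond the scatter in either direction. Compound 4 is expected to reach an efficacy of about 96%, with a likely range from 82% to 108%.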

Compound 4, largest response reached (reported as efficacy), in percent of the reference or control that the assay uses: 99%
For compound 4 the middle estimate is 3 percentage points below the measured one; the measured number falls inside the stated range.
By their numbers in this assay, from the lowest: compounds 1, 4, 2 and 3 (each within the scatter of the next).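

Hydrogen in place of methoxy on a saturated ring carbon of the four-membered ring gives, in this assay, a step of a number 6 percentage points higher from compound 1 to compound 4 (within the scatter). Going by these compounds alone, the earlier compounds offered no pair differing in one place, so this is the first direct reading at this position, and it shows that the largest response stays within the scatter when the methoxy and its 2 heavy atoms leave. No independent measurement bears on this result, so the step comes without an explanation.

Going by these compounds, it remains open whether an ethoxy group or an amine on the same ring carbon would also leave the largest response within the scatter of compound 1. On these data alone, it is equally open whether the exchange of methoxy for hydrogen would leave any read-out other than the largest response unchanged.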